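A few compounds are considered here, and "the series" means these few. Any claim that something is new, unique, unknown or untested is made for them only; others in the source may bear on it.

In a functional assay on HCT-116 cells (Homo sapiens) for cytotoxicity, read by MTT assay (on this read-out higher numbers stand for weaker inhibition and lower numbers for stronger inhibition), compound 1 (`Nc1ccccc1NC(=O)c1ccc(CSc2ccccn2)cc1`) gives 1000 nM, compound 2 (`Nc1nc(NCc2ccc(C(=O)Nc3ccccc3N)cc2)c2nc[nH]c2n1`) gives 10000 nM and compound 3 (`CCCCn1cnc2c(NCc3ccc(C(=O)Nc4ccccc4N)cc3)nc(N)nc21`) gives 2000 nM. Compound 3 thus lies within the scatter of compound 1 and clearly below compound 2. Compound 4 (`CCCCn1cnc2c(NCc3ccc(C(=O)Nc4ccccc4N)cc3)nc(Cl)nc21`) has chloro in place of amino on an aromatic carbon, between two ring nitrogen atoms: chloro in place of amino on an aromatic carbon. Within the data shown here, the only measured step, a 5.0-fold lower number from compound 2 to compound 3 (0.70 log units; beyond the scatter), is modest and comes from butyl in place of hydrogen on an aromatic nitrogen, a different change at a different place. Among the measured compounds shown here, with no measured precedent for this exchange, no shift beyond the scatter is expected in this assay. The expected step is a 1.3-fold lower number from compound 3 to compound 4 (0.12 log units; within the scatter). For compound 4 the estimated value is 1500 nM, with an expected range of 500 nM to 5000 nM.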

Compound 4, half-maximal inhibitory concentration: 100 nM
Compound 4: the middle estimate sits 15-fold (1.18 log units) above what was measured; measured number below the stated range.
By their numbers in this assay, from the lowest: compound 4; then compounds 1 and 3 (each within the scatter of the next); then compound 2.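

The change at this position is far from neutral in this assay: chloro in place of amino on an aromatic carbon, between two ring nitrogen atoms, gives a 20-fold lower number from compound 3 to compound 4 (1.30 log units; beyond the scatter) and is a large step. The earlier compounds shown here held this carbon fixed with amino, so they gave no sign of how much depended on it. Nothing measured here explains the step.

The compounds shown leave open whether fluoro, methoxy or hydrogen on this carbon would match chloro or amino. They also leave open whether chloro would bring a similar step with hydrogen instead of butyl on the aromatic nitrogen.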